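Sulfonyl aryl swaps on a shared bis-heteroaryl core

This account rests on a few compounds, and the source may have more. Where it says the series, first, only, none or still open, it means among the compounds named here.

Measured so far:
compound 1 `CN(c1ccc2[nH]c(-c3n[nH]c4ccccc34)cc2n1)S(=O)(=O)c1ccc(Br)cc1` — 6240 nM
compound 2 `COc1ccc(OC)c(S(=O)(=O)N(C)c2ccc3[nH]c(-c4n[nH]c5ccccc45)cc3n2)c1` — 840 nM

Two compounds have been run in a functional assay on HL-60 cells (Homo sapiens) for antiproliferative activity, read by MTT assay, with a stated time of 72 h (a lower number here means a stronger inhibitor, a higher number a weaker inhibitor), both sharing the same core and differing only in the aryl group on the sulfonyl sulfur. Compound 1 gives 6240 nM and compound 2 gives 840 nM. Within the data shown here, the single step between them, a 7.4-fold lower number from compound 1 to compound 2 (0.87 log units; beyond the scatter), shows that exchanging the aryl group on the sulfonyl sulfur can move the number well beyond the scatter. Among the measured compounds shown here, compound 2 therefore holds the lowest number of the two, with compound 1 the only neighbour.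

Compound 3 `CN(c1ccc2[nH]c(-c3n[nH]c4ccccc34)cc2n1)S(=O)(=O)c1cccc([N+](=O)[O-])c1` is the next member. It differs from compound 2 as follows: 3-nitrophenyl in place of 2,5-dimethoxyphenyl on a sulfonyl sulfur. For the measured compounds named here, the only step that bears on this change is the one from compound 1 to compound 2, also an aryl swap on the sulfonyl sulfur, which was modest in size. Going by the values given here, no measured step involves a nitro-bearing aryl group, so the direction is open. A step toward a higher number, of a size within that seen for compound 1 to compound 2, is the working expectation: for compound 3 the estimate is a 2.4-fold higher number from compound 2 to compound 3 (0.38 log units; beyond the scatter), giving 2000 nM with a range of 600 nM to 7000 nM.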

Compound 3, half-maximal inhibitory concentration: 3660 nM
Compound 3: the middle estimate sits 1.8-fold (0.26 log units) below what was measured, within the range that was stated.
By their numbers in this assay, from the lowest: compound 2; then compounds 3 and 1 (each within the scatter of the next).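

In this assay, replacing the 2,5-dimethoxyphenyl group on the sulfonyl sulfur with 3-nitrophenyl gives a 4.4-fold higher number from compound 2 to compound 3 (0.64 log units; beyond the scatter) and so marks a second step beyond the scatter at this position, with compound 2 now the strongest of the three. With a 1.7-fold lower number from compound 1 to compound 3 (0.23 log units; within the scatter) the 3-nitrophenyl and 4-bromophenyl groups cannot be told apart here, so two aryl groups with different substituents sit at one level and only 2,5-dimethoxyphenyl stands away from them. Nothing available here explains why the dimethoxy pattern differs from the other two.

The compounds shown leave open whether the 2,5-dimethoxyphenyl result depends on both methoxy groups or whether a single methoxy group on the phenyl ring would serve as well. They also leave open how this position responds to an amine or a carboxylic acid on the aryl ring, to an unsubstituted phenyl, or to a simple alkyl chain in place of the aryl group on the sulfonyl sulfur.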